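The source may hold more compounds than are shown below. What is called first, only, known or untested is meant among the compounds shown, and "the series" means these compounds.

In an assay on CHO cells for displacement of a labelled ligand from Substance-P receptor (Homo sapiens), in the presence of a further agent that is not named here (on this read-out lower numbers stand for stronger inhibition and higher numbers for weaker inhibition), the three measured compounds stand as follows:

Compound 1, `C[C@@H](O[C@H]1CN2C(=O)C=C(c3ccc(C#N)cc3)CC2[C@@H]1c1ccc(F)cc1)c1cc(C(F)(F)F)cc(C(F)(F)F)c1`, gives 53 nM.
Compound 2, `C[C@@H](O[C@H]1CN2C(=O)C=C(c3ccc(NS(C)(=O)=O)cc3)CC2[C@@H]1c1ccc(F)cc1)c1cc(C(F)(F)F)cc(C(F)(F)F)c1`, gives 54 nM.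
Compound 3, `C[C@@H](O[C@H]1CN2C(=O)C=C(c3ccc(CO)cc3)CC2[C@@H]1c1ccc(F)cc1)c1cc(C(F)(F)F)cc(C(F)(F)F)c1`, gives 23 nM.

Compound 3 thus carries the lowest number of the three. The two steps that lead to it were modest: a 2.3-fold lower number from compound 1 to compound 3 (0.36 log units; beyond the scatter), and a 2.3-fold lower number from compound 2 to compound 3 (0.37 log units; beyond the scatter), while a 1.0-fold higher number from compound 1 to compound 2 (0.01 log units; within the scatter). Compound 4, `C[C@@H](O[C@H]1CN2C(=O)C=C(c3cnn(C)c3)CC2[C@@H]1c1ccc(F)cc1)c1cc(C(F)(F)F)cc(C(F)(F)F)c1`, is reached from compound 3 by a change of a different kind: 1-methyl-1H-pyrazol-4-yl in place of 4-(hydroxymethyl)phenyl on a double-bonded ring carbon. Among the compounds with values here, no measured step exchanges the whole ring on that carbon, so the steps to compound 3 bear on the new case only in showing that the group on this part of the shared core shifts the numbers modestly rather than strongly. The expectation for compound 4 is therefore a step of a 2.0-fold higher number from compound 3 to compound 4 (0.29 log units; within the scatter), a modest move toward a higher number with wide uncertainty. Compound 4 is estimated at 45 nM, within a range from 15 nM to 140 nM.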

Compound 4, half-maximal inhibitory concentration: 5.4 nM
Compound 4: the middle estimate sits 8.3-fold (0.92 log units) above what was measured, outside the stated range (below it).
By their numbers in this assay, from the lowest: compound 4; then compound 3; then compounds 1 and 2 (each within the scatter of the next).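

In this assay, exchanging the whole ring on the double-bonded ring carbon gives a 4.3-fold lower number from compound 3 to compound 4 (0.63 log units; beyond the scatter), a 10-fold lower number from compound 2 to compound 4 (1.00 log units; beyond the scatter) and a 9.8-fold lower number from compound 1 to compound 4 (0.99 log units; beyond the scatter), all beyond the scatter. Compound 4 therefore shows that this position does not need a phenyl ring: 1-methyl-1H-pyrazol-4-yl, a five-membered aromatic ring with 2 hetero atoms, gives the lowest number of the four compounds, and it does so with fewer heavy atoms and no hydrogen-bond donor. Nothing measured here accounts for the gain.

The compounds shown leave open whether the gain belongs to the pyrazole ring itself or to its methyl group. They also leave open how an ethyl group in that place, or a pyridine ring on the same carbon, would read.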